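Removing the ring methyl: compound 2 to compound 3

The compounds below may be only part of what the source reports. "The series", "measured", "known", "first", "only" and "open" are said of these compounds alone.

Measured so far in a functional assay on MCF7 cells (Homo sapiens) for cytotoxicity, read by MTT assay, with a stated time of 72 h, tested at 3 uM; a higher number here means more inhibition of growth at the concentration tested, a lower number less inhibition of growth:
- compound 1 `Cc1cccc(/C(N)=N/NC(=S)N2CCSCC2)n1`: 20.6%
- compound 2 `Cc1ccnc(/C(N)=N/NC(=S)N2CCSCC2)c1`: 33.8%

Compound 2 stands highest of the two numbers in this assay; the nearest value, that of compound 1, lies lower by an amount beyond the usual scatter. Among the measured compounds shown here, both carry a methyl on the six-membered aromatic ring with 1 nitrogen, but at different places, and no step between them has been worked out, so only the two values themselves can be read.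

Compound 3 `N/C(=N\NC(=S)N1CCSCC1)c1ccccn1` differs from compound 2 in one place: hydrogen in place of methyl on an aromatic carbon, meta to a large group and opposite the ring nitrogen.

For the measured compounds named here, no step of this kind is available. The two values in hand suggest that the position of a methyl matters, but they give no reading of what losing the methyl altogether does. The expected step in this assay is therefore small, most likely a modest decrease, and possibly none beyond the scatter; the expected change is a number 6.8 percentage points lower from compound 2 to compound 3 (within the scatter). Compound 3 is estimated at 27%, with a range from 12% to 42%.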

Compound 3, percent growth inhibition at one concentration: 29%
Compound 3: middle estimate off by 2 percentage points, on the low side; the range from low to high includes it.
By their numbers in this assay, from the lowest: compounds 1, 3 and 2 (each within the scatter of the next, the first and the last beyond it).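

In this assay, hydrogen in place of methyl on an aromatic carbon, meta to a large group and opposite the ring nitrogen, gives a number 4.8 percentage points lower from compound 2 to compound 3 (within the scatter), so the methyl at this place is not needed for the growth inhibition seen with compound 2. The same kind of change, starting from the methyl at its other place in compound 1, gives a number 8.4 percentage points higher from compound 1 to compound 3 (within the scatter), so neither methyl stands apart from hydrogen in this series, and only compounds 1 and 2 lie apart from each other, beyond the scatter. Nothing at hand accounts for the size of either step.

On these data alone, whether a group other than methyl on this aromatic carbon, such as methoxy, chlorine or an amine, would move the number beyond the scatter remains open. Also open, as far as these compounds go, is whether a longer chain here, or a methyl on any other carbon of this ring, would leave this assay as flat as these two steps do.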